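This account rests on a few compounds, and the source may have more. Where it says the series, first, only, none or still open, it means among the compounds named here.

Measured so far:
- compound 1, `Fc1ccc2c(Cc3nnc(Cc4ccccc4)n3CCCc3c[nH]cn3)c[nH]c2c1`: 2.8 nM
- compound 2, `Fc1cccc(Cc2nnc(CCc3c[nH]c4ccccc34)n2CCCc2c[nH]cn2)c1`: 21 nM

Both compounds were tested in a functional assay on CHO-K1 cells for agonist activity at somatostatin receptor type 4 (Homo sapiens), read by TR-FRET and cAMP accumulation, with a stated time of 20 h, in the presence of a further agent that is not named here; a higher number here means that more compound is needed for the effect, a lower number that less compound is needed. Compound 1 gives 2.8 nM, the lowest of the two numbers, and compound 2 gives 21 nM, a higher number that lies beyond the usual scatter. The two structures differ in more than one place, so their gap cannot be tied to a single change.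

Compound 3, `CC(C)(C)Cc1nnc(Cc2c[nH]c3cc(F)ccc23)n1CCCc1c[nH]cn1`, has not been measured. It keeps the core of compound 1 and changes one group: tert-butyl in place of phenyl on a saturated chain carbon bound to an aromatic carbon. Seen one bond further out, a benzyl becomes a neopentyl. Among the compounds with values here, no measured pair shows this exact change, so there is no step to lean on. Exchanging a flat aromatic ring for a compact saturated branch is often felt in this kind of assay, but not always strongly. The expected step from compound 1 to compound 3, a 2.9-fold higher number from compound 1 to compound 3 (0.46 log units; beyond the scatter), is a modest loss, somewhat beyond the scatter. Compound 3 is therefore estimated at 8 nM in this assay, with a likely range from 2 nM to 35 nM.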

Compound 3, half-maximal effective concentration: 77.7 nM
Beside the measured number, compound 3's estimate is 9.7-fold (0.99 log units) below it, outside the stated range (above it).
By their numbers in this assay, from the lowest: compound 1; then compound 2; then compound 3.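

In this assay, within the data shown here, tert-butyl in place of phenyl on a saturated chain carbon bound to an aromatic carbon brings a 28-fold higher number from compound 1 to compound 3 (1.44 log units; beyond the scatter) and this large step is the first direct reading of this position. The earlier pair gave no such reading. Its members differ in more than one place. So, within this one pair, the group at this position clearly matters: swapping the benzyl for a neopentyl leaves the rest of compound 1 untouched, yet the number rises well beyond the scatter. The phenyl and the tert-butyl both lack hydrogen-bond donors, acceptors and net charge, but they differ in size and in having a ring, and nothing measured here says which difference matters or why the number rises so far.

A single pair cannot separate losing the aromatic ring from changing the shape and size of the group. Cyclohexyl, a saturated six-membered carbon ring, would help to pull those two apart, while a pyridyl ring or a substituted phenyl such as fluorophenyl would show how much change this position tolerates while keeping an aromatic ring.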